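Anilino variation on the shared core: fluoro to ethoxy

A few compounds are considered here, and "the series" means these few. Any claim that something is new, unique, unknown or untested is made for them only; others in the source may bear on it.

All values below come from a functional assay on HGC-27 cells (Homo sapiens) for cytotoxicity, read by MTT assay, with a stated time of 72 h; on this read-out lower numbers stand for stronger inhibition and higher numbers for weaker inhibition.

Compound 1 `CCCCCCNc1nc(SCc2ccc(C(F)(F)F)cc2)nc2ccccc12`: 23900 nM
Compound 2 `FC(F)(F)c1ccc(CSc2nc(Nc3cccc(C(F)(F)F)c3)c3ccccc3n2)cc1`: 11700 nM
Compound 3 `Fc1ccc(Nc2nc(SCc3ccc(C(F)(F)F)cc3)nc3ccccc23)cc1`: 19500 nM

Compound 3 stands second highest of the three numbers; its nearest neighbour is compound 1 and its furthest compound 2, and both of those gaps are within the scatter. Of the measured steps, a 1.2-fold lower number from compound 1 to compound 3 (0.09 log units; within the scatter) and a 1.7-fold higher number from compound 2 to compound 3 (0.22 log units; within the scatter) fall within the scatter, while a 2.0-fold lower number from compound 1 to compound 2 (0.31 log units; beyond the scatter) is modest and just beyond it. All three steps replace the whole group on the nitrogen on the aromatic ring; none exchanges one substituent on that ring for another.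

Compound 4 `CCOc1ccc(Nc2nc(SCc3ccc(C(F)(F)F)cc3)nc3ccccc23)cc1` is not yet measured. It differs from compound 3 by ethoxy in place of fluoro on an aromatic carbon. Going by the values given here, no measured step bears directly on this exchange, so the only guide is the narrow spread of the three numbers in this assay. The step is therefore expected to stay within the scatter, with no direction assigned, as a 1.1-fold lower number from compound 3 to compound 4 (0.06 log units; within the scatter). Compound 4 is estimated at 17000 nM in this assay, with a range from 7000 nM to 40000 nM.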

Compound 4, half-maximal inhibitory concentration: 33000 nM
Compound 4: middle estimate off by 1.9-fold (0.29 log units), on the low side; the measured number falls inside the stated range.
By their numbers in this assay, from the lowest: compounds 2, 3, 1 and 4 (each within the scatter of the next, the first and the last beyond it).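

Unlike the earlier steps, which replace the whole group on the nitrogen, this one exchanges a single substituent on the aromatic ring, para to a large group, and in this assay ethoxy in place of fluoro gives a 1.7-fold higher number from compound 3 to compound 4 (0.23 log units; within the scatter), so the exchange does not separate the two compounds despite the larger substituent. Going by these compounds alone, the 4-ethoxyphenyl group likewise cannot be told apart from hexyl on the nitrogen, with a 1.4-fold higher number from compound 1 to compound 4 (0.14 log units; within the scatter), but against the 3-(trifluoromethyl)phenyl group it shows a 2.8-fold higher number from compound 2 to compound 4 (0.45 log units; beyond the scatter), the only step among the new ones that clears the scatter, and it remains modest. No measurement is available that accounts for this result or for that gap.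

The step from compound 2 to compound 4 changes both the substituent and where it sits on the ring, so the compounds shown cannot assign the gap to either. Also open, as far as these compounds go, is whether an amine or a carboxylic acid at this place on the ring, or a longer alkoxy chain such as butoxy, would move the number beyond the scatter from compound 3.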